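Swapping the benzylic aryl of compound 3 for a fluorophenyl

This account rests on a few compounds, and the source may have more. Where it says the series, first, only, none or still open, it means among the compounds named here.

The series shares one core. Compound 1 `Nc1cc(N)c2nc(-c3ccccc3)c(Oc3ccc(Cl)c(Cl)c3)nc2c1` gives 26300 nM in a functional assay on MDA-MB-231 cells (Homo sapiens) for inhibition, read by sulforhodamine B assay, with a stated time of 48 h (on this read-out higher numbers stand for weaker inhibition of growth and lower numbers for stronger inhibition of growth), compound 2 `Nc1cc(N)c2nc(-c3ccccc3)c(Sc3ccc(F)cc3)nc2c1` gives 38000 nM, and compound 3 `COc1ccc(CNc2nc3cc(N)cc(N)c3nc2-c2ccccc2)cc1OC` gives 29500 nM. Compound 3 thus stands second highest of the three numbers, yet both of its neighbours lie within the scatter of it. Compound 4 `Nc1cc(N)c2nc(-c3ccccc3)c(NCc3ccc(F)cc3)nc2c1` differs from compound 3 by 4-fluorophenyl in place of 3,4-dimethoxyphenyl on a saturated chain carbon bound to a nitrogen on an aromatic ring. Among the compounds with values here, the one step that bears on this, an exchange of the pendant aryl on the same position of the core, was a 1.4-fold higher number from compound 1 to compound 2 (0.16 log units; within the scatter), so no movement beyond the scatter is anticipated here either. Compound 4 is therefore expected to give 30000 nM (range 15000 nM to 60000 nM), an estimated step of a 1.0-fold higher number from compound 3 to compound 4 (0.01 log units; within the scatter).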

Compound 4, concentration for total growth inhibition: 5130 nM
For compound 4 the middle estimate is 5.8-fold (0.77 log units) above the measured one; the measured number lies below the stated range.
By their numbers in this assay, from the lowest: compound 4; then compounds 1, 3 and 2 (each within the scatter of the next).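

Within this assay, 4-fluorophenyl in place of 3,4-dimethoxyphenyl on the saturated chain carbon gives the first step beyond the scatter in this series (a 5.8-fold lower number from compound 3 to compound 4 (0.76 log units; beyond the scatter)). The (4-fluorobenzyl)amino group on the aromatic carbon also separates from (4-fluorophenyl)sulfanyl (a 7.4-fold lower number from compound 2 to compound 4 (0.87 log units; beyond the scatter)) and from 3,4-dichlorophenoxy (a 5.1-fold lower number from compound 1 to compound 4 (0.71 log units; beyond the scatter)). No measurement given here accounts for these steps. As far as these compounds go, it remains open whether the fluorine itself matters or only the loss of the two methoxy groups, which a 4-chlorophenyl or a 4-methoxyphenyl on the same chain carbon could help to separate.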